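The source may hold more compounds than are shown below. What is called first, only, known or untested is meant among the compounds shown, and "the series" means these compounds.

Working notes on the series. In a functional assay on K562 cells (Homo sapiens) for antiproliferative activity, read by MTT assay, with a stated time of 72 h (a higher number here means a weaker inhibitor, a lower number a stronger inhibitor), compound 1 `COc1cc(-c2ncnn2-c2cccc(F)c2)cc(OC)c1OC` gives > 10000 nM, which is a limit and not a number. Compound 2 `COc1cc(-n2ncnc2-c2ccc(C)cc2)cc(OC)c1OC` gives > 10000 nM, which is also a limit. For the measured compounds named here, the series so far therefore stands at a single mark, (the limit of > 10000 nM in this assay, at which 2 of the 2 values shown sit), and compound 1 cannot be ranked any more finely than that.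

Compound 3 `COc1cc(-c2ncnn2-c2ccc(Cl)cc2Cl)cc(OC)c1OC` differs from compound 1 in one place: 2,4-dichlorophenyl in place of 3-fluorophenyl on an aromatic nitrogen. It has 2,4-dichlorophenyl in place of 3-fluorophenyl on an aromatic nitrogen, next to the ring atom that bears a large group. Going by the values given here, no measured pair shows the size of such a step. In this assay no step beyond the scatter is expected, and neither direction is favoured. The expected step is a number no higher from compound 1 to compound 3 (the limit leaves the size open). For compound 3 the estimate is 10000 nM, with an expected range from 3000 nM to 30000 nM.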

Compound 3, half-maximal inhibitory concentration: > 10000 nM
Compound 3: a limit, no number; the forecaster's own chance of this, stated with the estimate: 70%; the middle value lies on the limit itself.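

Compound 3 gives > 10000 nM in this assay, which is a limit and not a number, so the step from compound 1 to compound 3 cannot be read. The compounds shown leave open how any of them ranks against the others, because all share one mark: the limit of > 10000 nM in this assay, at which 3 of the 3 values shown sit.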